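A few compounds are considered here, and "the series" means these few. Any claim that something is new, unique, unknown or untested is made for them only; others in the source may bear on it.

Compounds measured so far:
- compound 1, `Oc1ccc(-c2cc(-c3cccc(O)c3)nc(-c3ccccc3O)c2)cc1`: 5830 nM
- compound 2, `Oc1cccc(-c2cc(-c3ccccc3O)cc(-c3ccccc3O)n2)c1`: 3390 nM
- compound 3, `Oc1ccc(-c2cc(-c3cccc(O)c3)cc(-c3cccc(O)c3)n2)cc1`: 3090 nM

All three values come from a functional assay on HCT-15 cells (Homo sapiens) for cytotoxicity, read by CCK-8 assay, with a stated time of 4 days; a lower number here means a stronger inhibitor, a higher number a weaker inhibitor. Within the data shown here, compound 3 gives the lowest of the three numbers, but its gaps to the others are small: to compound 2 it is within the scatter, and to compound 1 it is also within the scatter, so no compound can be called the strongest here.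

Compound 4, `Oc1cccc(-c2cc(-c3cccc(O)c3)nc(-c3ccccc3O)c2)c1`, has not yet been measured. It differs from compound 3 in one group: 2-hydroxyphenyl in place of 4-hydroxyphenyl on an aromatic carbon. The same kind of swap, 2-hydroxyphenyl in place of 4-hydroxyphenyl on an aromatic carbon, is seen once among the measured compounds, at a different place on the shared core: a 1.7-fold lower number from compound 1 to compound 2 (0.24 log units; within the scatter). That step was small and within the scatter. On this basis the change from compound 3 to compound 4 is expected to give at most a modest shift, likely toward a lower number but possibly none beyond the scatter, that is a 1.2-fold lower number from compound 3 to compound 4 (0.09 log units; within the scatter).

Compound 4 is therefore estimated to give 2500 nM in this assay, with a range from 1200 nM to 6000 nM.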

Compound 4, half-maximal inhibitory concentration: > 50000 nM
Compound 4: only a limit was reported; the forecaster's own chance of this, stated with the estimate: 3%; middle value at least 20-fold (1.30 log units) from the limit.
By their numbers in this assay, from the lowest: compounds 3, 2 and 1 (each within the scatter of the next). At a limit, above all of these: compound 4.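

In this assay, putting 2-hydroxyphenyl in place of 4-hydroxyphenyl next to the ring nitrogen, with two 3-hydroxyphenyl groups on the same ring, is far from a neutral swap: it gives an at least 16-fold higher number from compound 3 to compound 4 (1.20 log units; beyond the scatter). Compound 4 also stands apart from its other two neighbours, with an at least 14-fold higher number from compound 2 to compound 4 (1.16 log units; beyond the scatter) and with an at least 8.5-fold higher number from compound 1 to compound 4 (0.93 log units; beyond the scatter). The earlier compounds suggested that this swap changes little, but its outcome differs sharply between the two cases: the same change on two cores in this assay, a 1.7-fold lower number (0.24 log units; within the scatter) from compound 1 to compound 2 and an at least 16-fold higher number (1.20 log units; beyond the scatter) from compound 3 to compound 4, at least 27-fold (1.44 log units) apart, beyond the scatter of two such steps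

As far as these compounds go, for compound 4, > 50000 nM is a limit and not a number, so the full size of these steps stays open. Also open, from the compounds shown here alone, is whether a methoxy group or an amine in place of the hydroxyl of the 2-hydroxyphenyl group at this position would give a similar number.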